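The compounds below may be only part of what the source reports. "The series", "measured", "known", "first", "only" and "open" are said of these compounds alone.

In an ADME assay on microsomes from liver (Rattus norvegicus, strain Crj;CD(SD)) for metabolic stability, read by LC-MS, using NADPH, with a stated time of 30 min, tested at 0.1 uM (on this read-out lower numbers stand for a less stable compound and higher numbers for a more stable compound), two compounds on the shared core have been measured so far. Compound 1 `C[C@@]1(c2cc(NC(=O)c3ncc(C#N)cc3Cl)ccc2F)C=C(CF)OC(N)=N1` gives 49%. Compound 2 `C[C@@]1(c2cc(NC(=O)c3ccc(C#N)cn3)ccc2F)C=C(CF)OC(N)=N1` gives 55%, which places it level with compound 1 within the scatter. The next compound is compound 3 `C[C@@]1(c2cc(NC(=O)c3coc(CF)n3)ccc2F)C=C(CF)OC(N)=N1`. The change is 2-(fluoromethyl)-1,3-oxazol-4-yl in place of 5-cyanopyridin-2-yl on a carbonyl carbon.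

For the measured compounds named here, only one measured step bears on this change, and only loosely. It is a number 6 percentage points higher from compound 1 to compound 2 (within the scatter), with hydrogen in place of chloro on an aromatic carbon. That step lies within the scatter, but it leaves the 5-cyanopyridin-2-yl framework in place and so does not test a replacement of the whole group. Going by the values given here, no measured pair shows a direction for the exchange in compound 3. The expected step is therefore a number 2 percentage points higher from compound 2 to compound 3 (within the scatter), with no change beyond the scatter anticipated in this assay, although the uncertainty is wide. The estimated value for compound 3 is 57%, with an expected range from 35% to 78%.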

Compound 3, percent of the compound remaining: 39%
Estimate against measurement, compound 3: 18 percentage points above; measured number inside the range.
By their numbers in this assay, from the lowest: compounds 3, 1 and 2 (each within the scatter of the next, the first and the last beyond it).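

In this assay, for the compounds shown here, the carbonyl carbon whose other neighbour is the amide-type nitrogen now shows a replacement of the whole aromatic group, not just the loss of a chloro substituent, and the read-out responds: 2-(fluoromethyl)-1,3-oxazol-4-yl in place of 5-cyanopyridin-2-yl gives a number 16 percentage points lower from compound 2 to compound 3 (beyond the scatter), the first step in this short series to clear the scatter. Going by these compounds alone, measured against 3-chloro-5-cyanopyridin-2-yl, the same entering group gives a number 10 percentage points lower from compound 1 to compound 3 (within the scatter), so only one of the two comparisons supports a real difference, and the finding rests on the single pair of compound 2 and compound 3. No measurement at hand accounts for this step.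

The compounds shown do not separate the contribution of the five-membered aromatic ring from that of its fluoromethyl substituent, and an oxazole carrying a plain methyl or a hydrogen at that place would be needed to tell the two apart. Within the data shown here, also open is how other groups on this carbonyl carbon behave, such as a methoxy-substituted pyridine or a saturated ring amine, since the three compounds cover only two cyanopyridinyl groups and one oxazolyl group.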